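Exchanging the Side Chain of Compound 1

The compounds below may be only part of what the source reports. "The series", "measured", "known", "first", "only" and "open" are said of these compounds alone.

Of the compounds shown here, three with a shared core have been tested in a functional assay on the whole organism (Tail, strain ICR) with Mus musculus as the target, in the tail flick test, with a stated time of 150 min, at a dose of 25 umol/kg by the oral route; a higher number here means a stronger effect of the compound at the dose given, a lower number a weaker effect. Compound 1 `C[C@@H](O)[C@H](NC(=O)CN(c1nc(Cl)nc2[nH]cnc12)C1CC1)C(=O)O` gives 24%, the second highest of the three numbers. Compound 2 `NCCCC[C@H](NC(=O)CN(c1nc(Cl)nc2[nH]cnc12)C1CC1)C(=O)OCc1ccccc1` gives 9.88%, and compound 3 `O=C(CN(c1nc(Cl)nc2[nH]cnc12)C1CC1)N[C@@H](CCC(=O)OCc1ccccc1)C(=O)OCc1ccccc1` gives 44.5%; compound 1 therefore lies beyond the scatter from both, higher than compound 2 and lower than compound 3. Going by the values given here, the only measured step between compounds differing in a single place is a number 34.6 percentage points higher from compound 2 to compound 3 (beyond the scatter), a change in the side chain carried on the shared core.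

Compound 4 `CSCC[C@H](NC(=O)CN(c1nc(Cl)nc2[nH]cnc12)C1CC1)C(=O)O` has not yet been measured in this assay. It differs from compound 1 by 2-(methylsulfanyl)ethyl in place of 1-hydroxyethyl on a saturated chain carbon bound to an amide-type nitrogen and a carbonyl carbon. The step from compound 2 to compound 3 shows that exchanging the side chain can move the read-out by a large amount, but it concerns a different pair of groups, and compound 2 and compound 3 also differ from compound 1 and compound 4 elsewhere, so neither its size nor its direction can simply be carried over. Among the compounds with values here, no measured pair shows how the read-out answers the loss of a hydrogen-bond donor in this place. The expected step is therefore a number 6 percentage points higher from compound 1 to compound 4 (within the scatter), of uncertain direction and not clearly beyond the scatter. The estimate for compound 4 is 30%, with a range from 10% to 55%.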

Compound 4, a percentage reported as activity, at one dose (the size of the read-out at that dose, not a potency): 4.14%
Compound 4: the middle estimate sits 25.9 percentage points above what was measured; measured number below the stated range.
By their numbers in this assay, from the lowest: compounds 4 and 2 (each within the scatter of the next); then compound 1; then compound 3.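

In this assay, putting 2-(methylsulfanyl)ethyl in place of 1-hydroxyethyl on a saturated chain carbon bound to an amide-type nitrogen and a carbonyl carbon gives a number 19.9 percentage points lower from compound 1 to compound 4 (beyond the scatter), so the read-out responds to this position even when the rest of the molecule stays the same. Going by these compounds alone, the only earlier step between compounds differing in one place, a number 34.6 percentage points higher from compound 2 to compound 3 (beyond the scatter), ran upward and concerned other groups, whereas this one shows that a side-chain exchange can also lower the read-out, here with the free carboxylic acid retained in both compounds. The change alters several things at once, as the entering group has one more heavy atom, sulfur instead of oxygen and no hydrogen-bond donor, and the defined stereocentre of the leaving group goes with it, but nothing available separates these differences or explains the fall.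

As far as these compounds go, it remains open whether a plain ethyl chain, with neither the hydroxyl nor the sulfur, would fall nearer compound 1 or compound 4. From the compounds shown here alone, it is equally open how a side chain ending in an amine or a second carboxylic acid would behave at this position on the same acid-bearing scaffold.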